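Triazole replacement on the chain carbon of compound 1

The compounds below may be only part of what the source reports. "The series", "measured", "known", "first", "only" and "open" are said of these compounds alone.

Compound 1 `CC(C)C(c1nnc[nH]1)c1ccc(-c2ccc3cccc(F)c3c2)[nH]c1=O` gives 12 nM in an assay on CHO cells for displacement of a labelled ligand from prostaglandin E2 receptor EP3 subtype (Homo sapiens), read by radioligand binding (a lower number here means a stronger inhibitor, a higher number a weaker inhibitor), the second highest of three numbers; its nearest neighbour is compound 3 `CC(C)C(c1cnc(N)s1)c1ccc(-c2ccc3cccc(F)c3c2)[nH]c1=O` at 16 nM, and the furthest is compound 2 `CC(C)C(CC(N)=O)c1ccc(-c2ccc3cccc(F)c3c2)[nH]c1=O` at 5 nM. Compound 4 `CC(C)C(Cc1noc(=O)[nH]1)c1ccc(-c2ccc3cccc(F)c3c2)[nH]c1=O` carries the change (a group of 7 heavy atoms (3 carbon, 2 nitrogen, 2 oxygen; one five-membered aromatic ring with 3 hetero atoms) in place of a group of 5 heavy atoms (2 carbon, 3 nitrogen; one five-membered aromatic ring with 3 hetero atoms), on a saturated chain carbon bound to an aromatic carbon and a saturated chain carbon). Two measured steps replace the same group at the same carbon: a 2.4-fold lower number from compound 1 to compound 2 (0.38 log units; beyond the scatter), and a 1.3-fold higher number from compound 1 to compound 3 (0.12 log units; within the scatter). One exchange lowered the number modestly, the other left it within the scatter, so for compound 4 a modest lowering or no step beyond the scatter is expected in this assay. Compound 4 is estimated at 7 nM, with a range of 3 nM to 17 nM. The expected step is a 1.7-fold lower number from compound 1 to compound 4 (0.23 log units; within the scatter).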

Compound 4, inhibition constant: 34 nM
The estimate for compound 4 lay 4.9-fold (0.69 log units) below the measured number, outside the stated range (above it).
By their numbers in this assay, from the lowest: compound 2; then compounds 1 and 3 (each within the scatter of the next); then compound 4.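

In this assay compound 4 is the weakest of the four compounds, with each step beyond the scatter (a 2.8-fold higher number from compound 1 to compound 4 (0.45 log units; beyond the scatter); a 2.1-fold higher number from compound 3 to compound 4 (0.33 log units; beyond the scatter); a 6.8-fold higher number from compound 2 to compound 4 (0.83 log units; beyond the scatter)). For the compounds shown here, the earlier replacements of 4H-1,2,4-triazol-3-yl on this saturated chain carbon gave a lower number or stayed within the scatter, so this is the first exchange here to raise the number beyond it. The largest step is the one from carbamoylmethyl, so the group that enters in compound 4 does not keep the number reached with that group.

Going by these compounds, whether a carboxylic acid or a primary amine at this place would stand nearer compound 2 remains open. No evidence is available to explain the rise in the number.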